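The source may report more compounds than this note shows. Statements on the series, on what has been measured and on what is new or still open speak of the compounds shown alone.

The series is assayed in an assay on isolated protein for inhibition of polyamine deacetylase HDAC10 (Homo sapiens); on this read-out lower numbers stand for stronger inhibition and higher numbers for weaker inhibition. Compound 1, `COc1ccc(C(=O)c2ccc3c(ccn3S(=O)(=O)c3cccc(/C=C/C(=O)NO)c3)c2)cc1`, gives 5890 nM there. Compound 3, `COc1ccc(C(=O)c2ccc3c(ccn3S(=O)(=O)c3ccc(/C=C/C(=O)NO)cc3)c2)cc1`, returns only a limit of the assay in this assay, namely > 100000 nM. Compound 2, `Cc1ccc(C(=O)c2ccc3c(ccn3Cc3ccc(C(=O)NO)cc3)c2)cc1`, likewise returns only a limit in this assay, > 100000 nM, so no number is known for it. Compound 2 therefore sits at the limit described in the limit of > 100000 nM in this assay, at which 2 of the 3 values shown sit, together with compound 3, while compound 1 alone yields a measurable value.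

The next compound, compound 4, `COc1ccc(C(=O)c2ccc3c(ccn3Cc3ccc(C(=O)NO)cc3)c2)cc1OC`, differs from compound 2 in a single place: 3,4-dimethoxyphenyl in place of 4-methylphenyl on a carbonyl carbon. The rest of the shared core, including the benzyl-linked hydroxamic acid, is unchanged.

Among the compounds with values here, no measured step between two compounds in this set differs in one place, so no step size has been observed here. For compound 4 the step in this assay is expected to be small or none beyond the scatter, since compound 2 gives only > 100000 nM and the change is confined to the aryl group on the carbonyl carbon. Compound 4 is accordingly estimated to give 100000 nM in this assay, within a range of 30000 nM to 300000 nM, which would be a step of a number no higher from compound 2 to compound 4 (the limit leaves the size open).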

Compound 4, half-maximal inhibitory concentration: 18900 nM
Compound 4: the middle estimate sits 5.3-fold (0.72 log units) above what was measured; the measured number lies below the stated range.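

In this assay, the aryl group on the carbonyl carbon proves able to move the read-out: 3,4-dimethoxyphenyl in place of 4-methylphenyl gives an at least 5.2-fold lower number from compound 2 to compound 4 (0.72 log units; beyond the scatter). Within the data shown here, this is the first single-place change that can be read in the set, and compound 4, which carries the benzyl-linked hydroxamic acid, gives 18900 nM. The step gives only a minimum size, and how far it really reaches stays unknown because compound 2 stands at a limit and not at a number: the limit of > 100000 nM in this assay, at which 2 of the 4 values shown sit.

The compounds shown leave open whether a single methoxy group on this aryl ring would produce the same change, or whether both are needed. They also do not tell how an amine or a carboxylic acid in place of the methoxy groups would read in this assay, or whether the same exchange would have any comparable effect on a shared core carrying a different link to the hydroxamic acid.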